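The source may hold more compounds than are shown below. What is called first, only, known or untested is meant among the compounds shown, and "the series" means these compounds.

Compound 1 `Brc1ccccc1Cn1ccc2nc(-c3ccccc3)nc-2c1` carries a 2-bromophenyl on a saturated chain carbon bound to an aromatic nitrogen. In an ADME assay on MDBK cells (Bos taurus) for cytotoxicity (a lower number here means that less compound is tolerated, a higher number that more compound is tolerated), compound 1 gives > 100000 nM, which is a limit of the assay and not a number. Compound 2 `O=C(O)c1ccc(Cn2ccc3nc(-c4ccccc4)nc-3c2)cc1` shares the core of compound 1 and puts a different group in the same place. In this assay compound 2 gives > 100000 nM, again a limit rather than a measured number. Among the compounds with values here, compound 1 therefore stands at the limit of > 100000 nM in this assay, at which 2 of the 2 values shown sit, and since the only other value shown sits at that same limit, no order between the two compounds can be drawn, and no step with a number at both ends is available. Compound 3 `Clc1ccc(Cn2ccc3nc(-c4ccccc4)nc-3c2)s1` has not yet been measured in this assay. It differs from compound 1 by 5-chlorothiophen-2-yl in place of 2-bromophenyl on a saturated chain carbon bound to an aromatic nitrogen. With both measured compounds at the limit, the step of a number no higher from compound 1 to compound 3 (the limit leaves the size open) is expected to be none beyond the scatter. Compound 3 is estimated at 100000 nM, with an expected range from 30000 nM to 300000 nM, and most likely only a limit will be reported.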

Compound 3, half-maximal cytotoxic concentration: > 100000 nM
Compound 3: a limit, no number; the forecaster's own chance of this, stated with the estimate: 75%; the middle value lies on the limit itself.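

In this assay compound 3 gives > 100000 nM, again a limit of the assay and not a number. Within the data shown here, compound 1 also sits at a limit, so no step from compound 1 to compound 3 can be read. The compounds shown leave open whether the groups compared here differ in cytotoxicity at all, because all values share one limit: the limit of > 100000 nM in this assay, at which 3 of the 3 values shown sit.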